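The source may report more compounds than this note shows. Statements on the series, on what has been measured and on what is new or still open speak of the compounds shown alone.

Results in a functional assay on MCF7 cells (Homo sapiens) for cytotoxicity, read by MTT assay, with a stated time of 72 h (on this read-out lower numbers stand for stronger inhibition and higher numbers for weaker inhibition), for the compounds tested so far:
Compound 1 (`N#Cc1ccc(/C=N/NC(=O)Nc2cc3c(Nc4ccc(F)c(Cl)c4)ncnc3cc2O[C@H]2CCOC2)cc1`): "not determined" (no result reported)
Compound 2 (`O=C(N/N=C/c1cc(Br)c(O)c(Br)c1)Nc1cc2c(Nc3ccc(F)c(Cl)c3)ncnc2cc1O[C@H]1CCOC1`): 5910 nM

Among the compounds with values here, compound 2 at 5910 nM carries the only number in this small set. Compound 1 has no reported result, so compound 2 cannot be ranked against anything. The next compound to be tested is compound 3 (`O=C(N/N=C/c1ccc(O)cc1)Nc1cc2c(Nc3ccc(F)c(Cl)c3)ncnc2cc1O[C@H]1CCOC1`), which differs from compound 2 in one place (4-hydroxyphenyl in place of 3,5-dibromo-4-hydroxyphenyl on a carbon with a double bond to nitrogen) and has 4-hydroxyphenyl in place of 3,5-dibromo-4-hydroxyphenyl on a carbon with a double bond to nitrogen. Within the data shown here, no two measured compounds form a comparable pair, so the data offer no measured step by which to size this one. In this assay a modest step toward weaker inhibition is expected, not far beyond the usual scatter, although a result within the scatter would be no surprise. As an estimate, the expected change is a 1.4-fold higher number from compound 2 to compound 3 (0.13 log units; within the scatter) and it carries wide uncertainty. For compound 3 the estimated value is 8000 nM (expected range 2500 nM to 25000 nM) and the measurement is still to come.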

Compound 3, half-maximal inhibitory concentration: 910 nM
Estimate against measurement, compound 3: 8.8-fold (0.94 log units) above; the whole stated range lies above it.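

Within the data shown here, with 4-hydroxyphenyl in place of 3,5-dibromo-4-hydroxyphenyl on a carbon with a double bond to nitrogen, the data give a 6.5-fold lower number from compound 2 to compound 3 (0.81 log units; beyond the scatter) in this assay and this is the first measured size for a change at this position. The result shows that the group at this position matters in this pair, with the form lacking the two bromine atoms giving the stronger inhibition by a margin beyond the scatter, although a single pair can establish no wider trend. Nothing available here accounts for the size or direction of this step.

The compounds shown leave open whether a single bromine would retain part of the weaker inhibition seen with two, and whether the hydroxyl group is needed at all, as no compound carries an unsubstituted phenyl or a methoxy or amine group in place of that hydroxyl. Compound 1, which carries a nitrile, has no reported result and so cannot show how a ring with that group compares with those of compound 2 and compound 3.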